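The source may hold more compounds than are shown below. What is called first, only, known or untested is meant among the compounds shown, and "the series" means these compounds.

In a functional assay on MDA-MB-231 cells (Homo sapiens) for antiproliferative activity, read by MTT assay, with a stated time of 72 h (a lower number here means a stronger inhibitor, a higher number a weaker inhibitor), compound 1 `CC1=CC[C@H]2[C@H](CC[C@]2(C)O)C(C)(C)[C@@H]1CC[C@H]1[C@]2(C)CC[C@H](OC(=O)c3ccc(C)cc3)C(C)(C)O[C@H]2CC[C@@]1(C)O` gives 33400 nM, compound 2 `CC1=CC[C@H]2[C@@H]1CC=C(C)[C@@H](CC[C@H]1[C@]3(C)CC[C@H](OCc4ccccc4)C(C)(C)O[C@H]3CC[C@@]1(C)O)C2(C)C` gives 35700 nM and compound 3 `CC1=CC[C@H]2[C@H](CC[C@]2(C)O)C(C)(C)[C@@H]1CC[C@H]1[C@]2(C)CC/C(=N/OCc3ccccc3)C(C)(C)O[C@H]2CC[C@@]1(C)O` gives 38200 nM. Compound 1 therefore stands level with both others, as all three numbers lie within the usual scatter of one another. Compound 4 `CC1=CC[C@H]2[C@H](CC[C@]2(C)O)C(C)(C)[C@@H]1CC[C@H]1[C@]2(C)CC[C@H](OC(=O)c3ccc(C(F)(F)F)cc3)C(C)(C)O[C@H]2CC[C@@]1(C)O` keeps the core of compound 1 and changes one group: trifluoromethyl in place of methyl on an aromatic carbon. This puts trifluoromethyl in place of methyl on an aromatic carbon, para to a large group. For the measured compounds named here, no measured pair shows this change directly. With compound 2 at 35700 nM and compound 3 at 38200 nM sitting level with compound 1 at 33400 nM despite their different groups, no step beyond the scatter is expected in this assay. The estimated step is a 1.1-fold lower number from compound 1 to compound 4 (0.05 log units; within the scatter). Compound 4 is expected at 30000 nM, with an estimated range of 14000 nM to 55000 nM.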

Compound 4, half-maximal inhibitory concentration: 19500 nM
Estimate against measurement, compound 4: 1.5-fold (0.19 log units) above; low and high end bracket the measured number.
By their numbers in this assay, from the lowest: compounds 4, 1, 2 and 3 (each within the scatter of the next).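

Compound 1 and compound 4 differ in one place only, so this pair gives a direct reading of trifluoromethyl in place of methyl on an aromatic carbon, para to a large group. In this assay the change gives a 1.7-fold lower number from compound 1 to compound 4 (0.23 log units; within the scatter) and so leaves the two compounds level, even with a group of more heavy atoms at this position. No measurement available here offers an explanation for this result. Still open, as far as these compounds go, is whether an amine or a carboxylic acid on this aromatic carbon would move the number beyond the scatter.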